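Cytotoxicity limits in a small aryl series

The source may hold more compounds than are shown below. What is called first, only, known or untested is meant among the compounds shown, and "the series" means these compounds.

In an ADME assay on Raji cells (Homo sapiens) for cytotoxicity, with a stated time of 72 h (a lower number here means that less compound is needed, a higher number that more compound is needed for the effect), compound 1 (`Cc1cc(NC(=O)Nc2ccc(C)c(Cl)c2)c2ccccc2n1`) gives > 25000 nM, which is a limit and not a number. Compound 2 (`Cc1cc(NC(=O)Nc2ccc(N)cc2)c2ccccc2n1`) gives > 25000 nM, also a limit, so its position rests on no measured number. For the measured compounds named here, the series so far stands at the limit of > 25000 nM in this assay, at which 2 of the 2 values shown sit.

Compound 3 (`Cc1cc(NC(=O)Nc2cccc(Cl)c2)c2ccccc2n1`) has 3-chlorophenyl in place of 4-aminophenyl on an amide-type nitrogen. Going by the values given here, no pair differing in one place has yet been measured, so no step size can be read directly. In this assay the expected step is none beyond the scatter, with the estimate a number no higher from compound 2 to compound 3 (the limit leaves the size open). This expectation rests on the chlorine-bearing compound 1, whose limit is > 25000 nM. Compound 3 is estimated at 25000 nM, with an expected range of 12000 nM to 50000 nM.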

Compound 3, half-maximal effective concentration: 18000 nM
Compound 3: middle estimate off by 1.4-fold (0.14 log units), on the high side, within the range that was stated.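

For the compounds shown here, compound 3 is the first compound to give a measured number rather than a limit in this assay, so the aryl group on the amide-type nitrogen now has one point that is not a limit. 3-chlorophenyl in place of 4-aminophenyl on an amide-type nitrogen gives an at least 1.3-fold lower number from compound 2 to compound 3 (0.14 log units; that floor lies within the scatter) and hydrogen in place of methyl on an aromatic carbon gives an at least 1.3-fold lower number from compound 1 to compound 3 (0.14 log units; that floor lies within the scatter) as a second reading of the same kind. Both steps are floors set against limits, and the rest of the series stays at the ceiling: the limit of > 25000 nM in this assay, at which 2 of the 3 values shown sit.

From the compounds shown here alone, the true size of either step stays open, with compound 1 and compound 2 holding limits only. Also open, going by these compounds, is how a methoxy group or a carboxylic acid in place of the chlorine of compound 3 would read in this assay against compound 3.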